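From compound 3 to compound 4: a side-chain swap

A few compounds are considered here, and "the series" means these few. Any claim that something is new, unique, unknown or untested is made for them only; others in the source may bear on it.

In an ADME assay on MT4 cells (Homo sapiens) for cytotoxicity, read by MTT assay (a higher number here means that more compound is tolerated, a lower number that less compound is tolerated), compound 3 (`Cc1cc(C)cc(S(=O)(=O)c2c(C(=O)NC(c3ccc(Cl)cc3)C3CC3)[nH]c3ccc(Cl)cc23)c1`) gives > 47300 nM, and this reading is a limit, not a number. Compound 1 (`Cc1cc(C)cc(S(=O)(=O)c2c(C(=O)NCc3cccc(N)c3)[nH]c3ccc(Cl)cc23)c1`) gives > 53400 nM, which is also a limit. Compound 2 (`Cc1cc(C)cc(S(=O)(=O)c2c(C(=O)NCC(=O)NC(C)c3ccncc3)[nH]c3ccc(Cl)cc23)c1`) is the only one of the three with a number, 47000 nM.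

Compound 4 (`Cc1cc(C)cc(S(=O)(=O)c2c(C(=O)NCC(=O)NCc3ccccc3F)[nH]c3ccc(Cl)cc23)c1`) has not yet been measured. Its difference from compound 3 is a group of 12 heavy atoms (9 carbon, 1 nitrogen, 1 oxygen, 1 fluorine; one six-membered aromatic ring of carbon only) in place of a group of 11 heavy atoms (10 carbon, 1 chlorine; one three-membered non-aromatic ring of carbon only, one six-membered aromatic ring of carbon only), on an amide-type nitrogen. Compound 2 also carries a carbamoyl-bearing group on the amide-type nitrogen, which makes it the closest measured comparison.

Among the measured compounds shown here, three measured steps bear on the change. The only one with a usable floor is an at least 1.1-fold lower number from compound 1 to compound 2 (0.05 log units; that floor lies within the scatter). The other two are a step that the two limits leave unreadable from compound 1 to compound 3 and a number no lower from compound 2 to compound 3 (the limit leaves the size open), and neither has a readable size. For the measured compounds named here, no measured step therefore shows a change beyond the scatter, so none is expected here, although the limits leave the true sizes open.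

The expected step is an at least 1.1-fold lower number from compound 3 to compound 4 (0.05 log units; that floor lies within the scatter), with the reading resting mainly on compound 2 at 47000 nM. A limit is about as likely as a number. In this assay, compound 4 is estimated at 42000 nM, with an expected range of 20000 nM to 60000 nM.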

Compound 4, half-maximal cytotoxic concentration: > 47300 nM
Compound 4 was reported as a limit (the forecaster's own chance of this, stated with the estimate: 50%); middle value at least 1.1-fold (0.05 log units) from the limit.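

In this assay compound 4 gives > 47300 nM, which is a limit and not a number, so the ((2-fluorobenzyl)carbamoyl)methyl group on the amide-type nitrogen joins the limit readings rather than adding a second number to that of compound 2. With 2-fluorobenzyl in place of 1-(pyridin-4-yl)ethyl on an amide-type nitrogen, the series shows a number no lower from compound 2 to compound 4 (the limit leaves the size open), which gives a direction but no size. The steps that link compound 4 to compound 3 and to compound 1 cannot be read, because limits stand at both ends of each: the limit of > 47300 nM in this assay, at which 2 of the 4 values shown sit.

From the compounds shown here alone, how far compound 1, compound 3 and compound 4 lie from their limits stays open, so no order can be set among them. Also open, going by these compounds, is whether a carboxylic acid or a primary amine in place of 2-fluorobenzyl on that amide-type nitrogen would give a number in this assay rather than another limit.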